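A few compounds are considered here, and "the series" means these few. Any claim that something is new, unique, unknown or untested is made for them only; others in the source may bear on it.

Working notes on the series. In a functional assay on Jurkat cells (Homo sapiens) for activation, with a stated time of 24 h (on this read-out higher numbers stand for an effect only at larger amounts of compound and lower numbers for an effect already at smaller amounts), compound 1 `Oc1ccccc1CNc1ccc(-c2ccccc2)cc1` gives 1820 nM. Compound 2 `Oc1ccccc1CNc1ccc(-c2ccc(OC(F)(F)F)cc2)cc1` in this assay is reported as "not active" (no number reported) and carries no number, so on this read-out compound 2 stands without a measured position. The next step leads to compound 3 `CCCOc1ccc(-c2ccc(NCc3ccccc3O)cc2)cc1`: propyl in place of trifluoromethyl on an oxygen on an aromatic ring. Going by the values given here, no step between measured compounds stands behind this change, and with no number for compound 2 the size of the step in this assay cannot be stated; only compound 1 gives a measured anchor. For compound 3 the estimate in this assay is 5000 nM, with a range from 1500 nM to 30000 nM.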

Compound 3, half-maximal effective concentration: "not active" (no number reported)
Nothing numeric was reported for compound 3, and the estimate cannot be compared.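

In this assay compound 2 and compound 3 both stand as not active, so no step can be read between them. The compounds shown leave open how far either lies from compound 1 at 1820 nM on this read-out. No supporting data bear on this result.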